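Fluoro on the Indole of Compound 2

A few compounds are considered here, and "the series" means these few. Any claim that something is new, unique, unknown or untested is made for them only; others in the source may bear on it.

Of the compounds shown here, three sharing one core have been tested in an ADME assay on SH-SY5Y cells (Homo sapiens) for cytotoxicity, read by MTT assay, with a stated time of 72 h; on this read-out lower numbers stand for stronger inhibition and higher numbers for weaker inhibition. Compound 1 `O=C(CN1CCN(C(=O)c2ccc(Cl)cc2)CC1)N1CCN(CCCc2c[nH]c3ccccc23)CC1` gives 139000 nM, compound 2 `COc1ccc(C(=O)N2CCN(CC(=O)N3CCN(CCCc4c[nH]c5ccccc45)CC3)CC2)cc1` gives 148000 nM and compound 3 `O=C(CN1CCN(C(=O)c2ccccc2F)CC1)N1CCN(CCCc2c[nH]c3ccccc23)CC1` gives 82600 nM. Compound 2 cannot be told apart from the other two, as the gaps around it show: a 1.1-fold higher number from compound 1 to compound 2 (0.03 log units; within the scatter) and a 1.8-fold lower number from compound 2 to compound 3 (0.25 log units; within the scatter).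

Compound 4 `COc1ccc(C(=O)N2CCN(CC(=O)N3CCN(CCCc4c[nH]c5ccc(F)cc45)CC3)CC2)cc1` keeps all of compound 2 except for one small edit: fluoro in place of hydrogen on an aromatic carbon. This is fluoro in place of hydrogen on an aromatic carbon, which turns 1H-indol-3-yl into 5-fluoro-1H-indol-3-yl. For the measured compounds named here, no measured step touches this part of the molecule, so the evidence is only indirect. The measured changes all lie on the group attached to the carbonyl carbon, and the third of them is a 1.7-fold lower number from compound 1 to compound 3 (0.23 log units; within the scatter). Together, these three steps suggest that this assay has responded little to edits so far, though they say nothing direct about fluoro on the indole. A step beyond the scatter is therefore not expected, in either direction. The estimated change is a 1.1-fold lower number from compound 2 to compound 4 (0.06 log units; within the scatter). Compound 4 is expected to give 130000 nM, with an estimated range from 65000 nM to 230000 nM.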

Compound 4, half-maximal inhibitory concentration: 161000 nM
Compound 4: the middle estimate sits 1.2-fold (0.09 log units) below what was measured; low and high end bracket the measured number.
By their numbers in this assay, from the lowest: compounds 3, 1, 2 and 4 (each within the scatter of the next).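

The first step measured on the indole rather than on the group attached to the carbonyl carbon stays within the scatter in this assay (a 1.1-fold higher number from compound 2 to compound 4 (0.04 log units; within the scatter)). Swapping hydrogen for fluoro on this six-membered aromatic ring, turning 1H-indol-3-yl into 5-fluoro-1H-indol-3-yl, therefore gives no detectable change in this read-out, so this position now has one direct measurement rather than only indirect hints from the other end of the molecule. No accompanying measurement is available to explain this outcome.

The compounds shown cover only one replacement at this position, so it remains open whether a different group there, such as an amine, a carboxylic acid or a methoxy group, would also stay within the scatter. On these data alone, it is equally open whether fluoro would give the same result on another carbon of the indole, or with the 4-chlorophenyl or 2-fluorophenyl group of compound 1 or compound 3 on the carbonyl carbon, or whether a longer chain leading to the indole would shift the number.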